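Notes on the stilbene anilide series: thiazole for trifluoromethylphenyl

A few compounds are considered here, and "the series" means these few. Any claim that something is new, unique, unknown or untested is made for them only; others in the source may bear on it.

Measured so far:
- compound 1 `COC(=O)/C=C/c1cccc(N(Cc2ccc(/C=C/c3cccc(C(F)(F)F)c3)cc2)C(=O)C(C)C)c1`: 267 nM
- compound 2 `COC(=O)/C=C/c1cccc(N(Cc2ccc(/C=C/c3cccc(C(F)(F)F)c3)cc2)C(=O)NC(C)C)c1`: 932 nM

In an assay on isolated protein with Bile acid receptor (Homo sapiens) as the target (on this read-out higher numbers stand for an effect only at larger amounts of compound and lower numbers for an effect already at smaller amounts), compound 1 gives 267 nM and holds the lowest of the two numbers recorded; the nearest is compound 2, reached through a 3.5-fold higher number from compound 1 to compound 2 (0.54 log units; beyond the scatter), a change at the carbonyl carbon only.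

Compound 3 `COC(=O)/C=C/c1cccc(N(Cc2ccc(/C=C/c3scnc3C)cc2)C(=O)C(C)C)c1` is not yet measured. It differs from compound 1 at the far end of the ethenyl chain: 4-methyl-1,3-thiazol-5-yl in place of 3-(trifluoromethyl)phenyl on a double-bonded chain carbon bound to a double-bonded chain carbon. For the measured compounds named here, no measured pair touches this part of the molecule; the single recorded step concerns the acyl group and says nothing about the distal aryl ring. The expectation for compound 3 therefore rests on compound 1 alone, with a wide range on either side.

Working estimate: compound 3 is expected to show a modest rise, about a 2.2-fold higher number from compound 1 to compound 3 (0.35 log units; beyond the scatter), since the smaller five-membered heteroaryl group has no precedent here. Compound 3 is thus estimated at 600 nM, within a range from 150 nM to 2500 nM.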

Compound 3, half-maximal effective concentration: 228 nM
The estimate for compound 3 lay 2.6-fold (0.42 log units) above the measured number; the range from low to high includes it.
By their numbers in this assay, from the lowest: compounds 3 and 1 (each within the scatter of the next); then compound 2.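

In this assay the far end of the ethenyl chain, which the earlier pair left untouched, proves open to change: 4-methyl-1,3-thiazol-5-yl in place of 3-(trifluoromethyl)phenyl on a double-bonded chain carbon bound to a double-bonded chain carbon gives a 1.2-fold lower number from compound 1 to compound 3 (0.07 log units; within the scatter) and leaves the two compounds level. The entering group has fewer heavy atoms, one five-membered aromatic ring with 2 hetero atoms against one six-membered aromatic ring of carbon only, and 2 hydrogen-bond acceptors against 0, so in this pair neither the trifluoromethyl group nor the six-membered ring is needed to hold the number. Nothing at hand accounts for the two groups reading alike.

Open, from the compounds shown here alone, is whether 4-methyl-1,3-thiazol-5-yl reads the same when the isopropyl on the carbonyl carbon gives way to the isopropylamino of compound 2. The compounds shown also leave open what the methyl on the thiazole contributes, how a pyridine would read at this place, and what a carboxylic acid would do in place of the methyl ester.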